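This account rests on a few compounds, and the source may have more. Where it says the series, first, only, none or still open, it means among the compounds named here.

Measured so far:
compound 1 `COc1cc(CNC(=O)CCCCCCC(C)C)ccc1OC(=O)CCC(=O)Oc1ccc(-c2cc(=S)ss2)cc1`, 2560 nM in a functional assay on MCF7 cells (Homo sapiens) for antiproliferative activity, read by MTT assay, with a stated time of 48 h; a higher number here means a weaker inhibitor, a lower number a stronger inhibitor
compound 2 `COc1cc(CNC(=O)CCCC/C=C/C(C)C)ccc1OC(=O)CCC(=O)Oc1ccc(-c2cc(=S)ss2)cc1`, 2120 nM
compound 3 `COc1cc(CNC(=O)CCCC/C=C/C(C)C)ccc1OCCCCCOc1ccc(C(N)=S)cc1`, 17200 nM

Compounds 1 and 2 share one core and differ in a single place: isopentyl in place of 3-methylbut-1-en-1-yl on a saturated chain carbon, four bonds along the chain from a carbonyl carbon. That change gave a 1.2-fold higher number from compound 2 to compound 1 (0.08 log units; within the scatter). Compound 3 carries a different core; how the two cores differ is not broken down here, but compound 3 sits highest of the three, with its nearest neighbour compound 1 well beyond the scatter. Compound 4 `COc1cc(CNC(=O)CCCCCCC(C)C)ccc1OCCCCCOc1ccc(C(N)=S)cc1` is not yet measured. It arises from compound 3 by the same change, (isopentyl in place of 3-methylbut-1-en-1-yl on a saturated chain carbon, four bonds along the chain from a carbonyl carbon), made once already between compound 2 and compound 1. Because that earlier step was a 1.2-fold higher number from compound 2 to compound 1 (0.08 log units; within the scatter), compound 4 is expected to stay close to compound 3, with an estimated step of a 1.2-fold higher number from compound 3 to compound 4 (0.07 log units; within the scatter). The estimate for compound 4 is therefore 20000 nM, between 9000 nM and 45000 nM.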

Compound 4, half-maximal inhibitory concentration: 49300 nM
The estimate for compound 4 lay 2.5-fold (0.39 log units) below the measured number; the whole stated range lies below it.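

Replacing 3-methylbut-1-en-1-yl with isopentyl on the core of compound 3 gave a 2.9-fold higher number from compound 3 to compound 4 (0.46 log units; beyond the scatter) in this assay, a modest step, whereas the same change on the other core stayed within the scatter. Set side by side, the two steps differ by no more than repeated measurements could produce: the same change on two cores in this assay, a 1.2-fold higher number (0.08 log units; within the scatter) from compound 2 to compound 1 and a 2.9-fold higher number (0.46 log units; beyond the scatter) from compound 3 to compound 4, 2.4-fold (0.38 log units) apart, within the scatter of two such steps. The data therefore give no sign that the change behaves differently on the two cores, but two pairs cannot prove that it carries over unchanged to others in this series.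

Still open, going by these compounds, is how a longer chain, an amine or a carboxylic acid in place of isopentyl would affect the number on either core.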